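The source may report more compounds than this note shows. Statements on the series, on what has been measured and on what is new or still open speak of the compounds shown alone.

Compound 1 `CN1C[C@H](C(=O)Nc2ccc(C(F)(F)F)cc2)[C@@H](c2ccc(/C=C/C(=O)Nc3ccccc3N)cc2)C1`: 23 mL/min/kg
Compound 2 `Cc1cc(NC(=O)[C@H]2CN(C)C[C@@H]2c2ccc(/C=C/C(=O)Nc3ccccc3N)cc2)ccc1F`: 62 mL/min/kg
Compound 3 `CN1C[C@H](C(=O)Nc2ccc(F)cc2F)[C@@H](c2ccc(/C=C/C(=O)Nc3ccccc3N)cc2)C1`: 27 mL/min/kg

In an in vitro ADME assay on microsomes from liver (Mus musculus) for pharmacokinetics, read by LC-MS, with a stated time of 10 min, tested at 1 uM (a lower number here means slower removal, a higher number faster removal of the compound), compound 3 gives 27 mL/min/kg, which lies within the scatter of compound 1 at 23 mL/min/kg and clearly under compound 2 at 62 mL/min/kg. The next compound in the series, compound 4 `CN1C[C@H](C(=O)NC2CC2)[C@@H](c2ccc(/C=C/C(=O)Nc3ccccc3N)cc2)C1`, has not yet been measured. It differs from compound 3 at a single place: cyclopropyl in place of 2,4-difluorophenyl on an amide-type nitrogen. In words, cyclopropyl stands in place of 2,4-difluorophenyl on an amide-type nitrogen.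

Going by the values given here, three measured steps bear on this change, since all of them exchange the group on that same nitrogen. They are a 1.2-fold higher number from compound 1 to compound 3 (0.07 log units; within the scatter), a 2.7-fold higher number from compound 1 to compound 2 (0.43 log units; beyond the scatter) and a 2.3-fold lower number from compound 2 to compound 3 (0.36 log units; beyond the scatter). The largest of these is modest, and the step of a 1.2-fold higher number from compound 1 to compound 3 (0.07 log units; within the scatter) stays within the scatter. All three exchange one substituted phenyl group for another, however, so none shows what cyclopropyl does, and they offer only a rough guide. On these data alone, on that basis no step beyond the scatter is expected in this assay, and the direction remains open, although a wide range is warranted. The expected step is a 1.1-fold lower number from compound 3 to compound 4 (0.05 log units; within the scatter). For compound 4 the estimated clearance is 24 mL/min/kg, with an expected range from 11 mL/min/kg to 52 mL/min/kg.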

Compound 4, clearance: 7 mL/min/kg
Estimate against measurement, compound 4: 3.4-fold (0.54 log units) above; measured number outside the range, below it.
By their numbers in this assay, from the lowest: compound 4; then compounds 1 and 3 (each within the scatter of the next); then compound 2.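

In this assay, going by these compounds alone, cyclopropyl is the first group on this amide-type nitrogen that is not a substituted phenyl, and it gives a 3.9-fold lower number from compound 3 to compound 4 (0.59 log units; beyond the scatter), a 3.3-fold lower number from compound 1 to compound 4 (0.52 log units; beyond the scatter) and an 8.9-fold lower number from compound 2 to compound 4 (0.95 log units; beyond the scatter). The earlier exchanges, all from one substituted phenyl to another, moved the number up in a 2.7-fold higher number from compound 1 to compound 2 (0.43 log units; beyond the scatter) and down in a 2.3-fold lower number from compound 2 to compound 3 (0.36 log units; beyond the scatter), whereas all three steps to cyclopropyl run downward and lie beyond the scatter, so compound 4 has the lowest number of the four. No measurement shown here accounts for this drop.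

Within the data shown here, with only one non-aromatic group at this position, the compounds leave open whether the low number belongs to cyclopropyl itself or extends to groups such as cyclobutyl, cyclohexyl, isopropyl or a longer alkyl chain. They also leave open how an unsubstituted phenyl, or a cyclopropyl carrying an amine or a carboxylic acid, would compare in this assay.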